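Exchanging the ring on the amide nitrogen of compound 2

The compounds below may be only part of what the source reports. "The series", "measured", "known", "first", "only" and "open" are said of these compounds alone.

Measured compounds:
compound 1, `O=C(NCCCCc1ccccc1)c1cc(F)cc(C2SCC(=O)N2c2ccccn2)c1`, 14.2 nM
compound 2, `CC(C)(C)c1conc1N1C(=O)CSC1c1cccc(C(=O)NCCCCc2ccccc2)c1`, > 1000 nM
compound 3, `CCOC(=O)c1sc(N2C(=O)CSC2c2cccc(C(=O)NCCCCn3cccn3)c2)nc1C`, 430 nM

In a functional assay on HOS-TE85 cells (Homo sapiens) for inhibition, read by CCK-8 assay, with a stated time of 72 h (on this read-out lower numbers stand for stronger inhibition and higher numbers for weaker inhibition), compound 1 gives 14.2 nM. Compound 3 gives 430 nM in this assay. For compound 2 only a limit is known, > 1000 nM, the point at which measurement stops; among the three values shown, this is the limit of > 1000 nM in this assay, at which 1 of the 3 values shown sits. Compound 2 therefore stands at the weak end of what has been measured, while compound 1 stands at the strong end and compound 3 in between.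

The unmeasured compound 4, `CC(F)(F)c1cccc(N2C(=O)CSC2c2cccc(C(=O)NCCCCc3ccccc3)c2)c1`, differs from compound 2 in one place: a group of 10 heavy atoms (8 carbon, 2 fluorine; one six-membered aromatic ring of carbon only) in place of a group of 9 heavy atoms (7 carbon, 1 nitrogen, 1 oxygen; one five-membered aromatic ring with 2 hetero atoms), on an amide-type nitrogen in a ring. The group enters on an amide-type nitrogen in a ring of a five-membered non-aromatic ring with 1 nitrogen and 1 sulfur, next to the ring atom that bears a large group, two ring bonds from the ring sulfur.

Among the measured compounds shown here, no measured pair shows a change exactly like this one. What is shown is that compound 1 and compound 3, each carrying a different ring on that nitrogen, reach measurable inhibition, whereas compound 2 gives only a limit. From this the step from compound 2 to compound 4 is expected to be a gain beyond the scatter, an at least 5.0-fold lower number from compound 2 to compound 4 (0.69 log units; beyond the scatter), toward stronger inhibition. Compound 4 is therefore estimated at 200 nM in this assay, within a range from 30 nM to 1500 nM.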

Compound 4, half-maximal inhibitory concentration: 29.1 nM
Beside the measured number, compound 4's estimate is 6.9-fold (0.84 log units) above it, and the stated range ends above it.
By their numbers in this assay, from the lowest: compound 1; then compound 4; then compound 3. At a limit, above all of these: compound 2.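

Compound 1 and compound 3 each differ from compound 2 in more than one place, so they could not tie a change in inhibition to the ring on the amide-type nitrogen alone. Here only that group changes: in this assay, a six-membered aromatic ring of carbon only, in place of a five-membered aromatic ring with 2 hetero atoms, gives an at least 34-fold lower number from compound 2 to compound 4 (1.53 log units; beyond the scatter), which shows that this position alone can move inhibition by a large margin. The true size of this gain is unknown, because compound 2 stands at a limit and not at a number: the limit of > 1000 nM in this assay, at which 1 of the 4 values shown sits.

The compounds shown do not separate the effect of the carbon-only ring from that of the fluorine-bearing group it carries, so a plain phenyl ring on that nitrogen, or the same ring carrying a methoxy group or a nitrile, would help to tell the two apart. Also open, going by these compounds, is whether this position needs an aromatic ring at all, a question that a cyclohexyl ring in the same place could answer.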